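The compounds below may be only part of what the source reports. "The series", "measured", "known", "first", "only" and "open" are said of these compounds alone.

Compounds measured in a functional assay on Col1 cells (Homo sapiens) for cytotoxicity, read by sulforhodamine B assay, with a stated time of 72 h; on this read-out higher numbers stand for an effect only at larger amounts of compound and lower numbers for an effect already at smaller amounts:

compound 1, `CCCC[C@H](OC(C)=O)[C@@H](O)[C@H](O)[C@@H]1OC(=O)C=C[C@@H]1OC(C)=O`: 5.1 ug/mL
compound 2, `CCCC[C@@H](/C=C\[C@@H]1OC(=O)C=C[C@@H]1O)OC(C)=O`: 1.6 ug/mL
compound 3, `CCCC[C@@H](/C=C\[C@@H]1OC(=O)C[C@@H](OC)[C@@H]1O)OC(C)=O`: > 20 ug/mL

Compound 2 stands at the lower of the two numbers that this assay has produced. Its nearest neighbour is compound 1, which gives a higher number, and that gap lies beyond the usual scatter of the measurement. For compound 3 this assay reports only a limit, not a number, so it is a third value of a different kind, and it cannot be placed against the other two.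

The unmeasured compound 4, `CCCC[C@@H](/C=C\[C@@H]1OC(=O)C=C[C@@H]1OC(C)=O)OC(C)=O`, is reached from compound 2 by one change: acetyl in place of hydrogen on an oxygen on a saturated carbon. Within the data shown here, no step between measured compounds shows what this change does on its own, so the expectation rests on compound 2 and the size of the changes seen so far. The account expects a modest step from compound 2 to compound 4 in this assay, a 1.6-fold higher number from compound 2 to compound 4 (0.19 log units; within the scatter), most likely within the scatter or only a little beyond it, with the number drifting upward rather than downward. Compound 4 is therefore expected to give 2.5 ug/mL, with a range from 0.8 ug/mL to 8 ug/mL.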

Compound 4, concentration for half-maximal effect: 1 ug/mL
For compound 4 the middle estimate is 2.5-fold (0.40 log units) above the measured one, and the stated range covers the measured number.
By their numbers in this assay, from the lowest: compounds 4 and 2 (each within the scatter of the next); then compound 1. At a limit, above all of these: compound 3.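

In this assay, among these compounds, replacing hydroxy with acetoxy on the oxygen on a saturated carbon gives the first direct reading at this position: a 1.6-fold lower number from compound 2 to compound 4 (0.20 log units; within the scatter). Within this pair, therefore, the free hydroxy is not needed to keep the number in the range of compound 2, and the added acetyl, with its three heavy atoms, leaves the two compounds indistinguishable on this read-out. Compound 1 and compound 3 differ from compound 2 in more than one place and could not isolate this change, and nothing measured here explains why the two values stay so close.

From the compounds shown here alone, it remains open whether the tolerance at this oxygen extends beyond acetyl, for example to a longer acyl chain such as butyryl, to a benzoyl group or to a simple methyl ether, or whether an amine in place of the oxygen would fit as well. Going by these compounds, it is also open whether the same exchange would behave alike on the differing core of compound 1 or compound 3, since the step is read on this single pair only.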